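This account rests on a few compounds, and the source may have more. Where it says the series, first, only, none or still open, it means among the compounds named here.

Measured in a functional assay on WI-38 VA13 cells (Homo sapiens) for cytotoxicity; on this read-out lower numbers stand for an effect already at smaller amounts and higher numbers for an effect only at larger amounts of compound:
Compound 1, `Cn1ncc([N+](=O)[O-])c1C(=O)Nc1ccc2nc(NC(=O)C3CCCCC3)sc2c1`, gives 0.026 ug/mL.
Compound 2, `O=C(Nc1ccc2nc(NC(=O)C3CCCCC3)sc2c1)c1ccccc1Cl`, gives 0.025 ug/mL.
Compound 3, `O=C(Nc1ccc2nc(NC(=O)C3CCCCC3)sc2c1)c1ccc(Cl)cc1Cl`, reaches only an assay limit, > 4 ug/mL, and so has no number.

Compound 2 has the lowest of the two numbers here, and compound 1 lies within the scatter of it, so the two cannot be ranked. Compound 4, `CC(C)COC(=O)Nc1ccc2nc(NC(=O)C3CCCCC3)sc2c1`, differs from compound 2 in one place: isobutoxy in place of 2-chlorophenyl on a carbonyl carbon. For the measured compounds named here, no measured step covers this exact change. The exchange of one carbonyl substituent for another gave a 1.0-fold lower number from compound 1 to compound 2 (0.02 log units; within the scatter), whereas adding a single chloro gave an at least 160-fold higher number from compound 2 to compound 3 (2.20 log units; beyond the scatter), with compound 3 sitting at the limit of > 4 ug/mL in this assay, at which 1 of the 3 values shown sits. The change to compound 4 removes the aromatic ring entirely rather than exchanging one ring for another, so the outcome is uncertain; a step beyond the scatter toward a higher number is expected, a 6.0-fold higher number from compound 2 to compound 4 (0.78 log units; beyond the scatter), with a real chance of reaching only a limit. Compound 4 is therefore estimated at 0.15 ug/mL, expected between 0.02 ug/mL and 2 ug/mL.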

Compound 4, half-maximal effective concentration: 0.72 ug/mL
For compound 4 the middle estimate is 4.8-fold (0.68 log units) below the measured one, within the range that was stated.
By their numbers in this assay, from the lowest: compounds 2 and 1 (each within the scatter of the next); then compound 4. At a limit, above all of these: compound 3.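

In this assay, for the compounds shown here, compound 4 is the first compound here with no ring on this carbonyl carbon, and the open isobutoxy group sits clearly worse than either ring-bearing partner: a 29-fold higher number from compound 2 to compound 4 (1.46 log units; beyond the scatter), and a 28-fold higher number from compound 1 to compound 4 (1.44 log units; beyond the scatter). A ring alone does not secure a low number, however, and compound 3 goes against that pattern, with an at least 5.5-fold lower number from compound 3 to compound 4 (0.74 log units; beyond the scatter). Compound 3 gives only a limit, not a number: the limit of > 4 ug/mL in this assay, at which 1 of the 4 values shown sits.

Still open, as far as these compounds go, is whether the step from compound 2 to compound 4 follows the loss of the ring or the entry of the oxygen, since both changes come together in compound 4. A phenoxy group or a plain pentyl chain on this carbonyl carbon would separate the two.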